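A few compounds are considered here, and "the series" means these few. Any claim that something is new, unique, unknown or untested is made for them only; others in the source may bear on it.

Among the measured compounds shown here, in a functional assay on A549 cells (Homo sapiens) for inhibition, read by MTT assay, with a stated time of 24 h (a higher number here means a weaker inhibitor, a lower number a stronger inhibitor), compound 1 (`CC1(C)[C@H]2CC[C@]1(C)N(Cc1cn(-c3ccccc3Cl)nn1)C(=O)C2`) gives 70 nM and compound 2 (`CC1(C)[C@H]2CC[C@]1(C)N(Cc1cn(-c3cccc(O)c3)nn1)C(=O)C2`) gives 180 nM as the higher of the two numbers so far. Compound 3 (`COc1ccc(-n2cc(CN3C(=O)C[C@@H]4CC[C@@]3(C)C4(C)C)nn2)cc1`) keeps the shared core and carries 4-methoxyphenyl in place of 3-hydroxyphenyl on an aromatic nitrogen. For the measured compounds named here, the one measured step at this place is a 2.6-fold higher number from compound 1 to compound 2 (0.41 log units; beyond the scatter) and it is modest, though it involves a different pair of groups. Going by the values given here, no measured compound carries 4-methoxyphenyl, so the direction is only weakly fixed. Among the compounds with values here, a step of similar or smaller size is expected in this assay and, with compound 2 at 180 nM at the top of only two values, the lean is toward a lower number. The estimated change is a 1.5-fold lower number from compound 2 to compound 3 (0.18 log units; within the scatter) as a working figure. Compound 3 is estimated at 120 nM with an expected range from 45 nM to 320 nM for now.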

Compound 3, half-maximal inhibitory concentration: 50 nM
Estimate against measurement, compound 3: 2.4-fold (0.38 log units) above, within the range that was stated.
By their numbers in this assay, from the lowest: compounds 3 and 1 (each within the scatter of the next); then compound 2.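

Exchanging 3-hydroxyphenyl for 4-methoxyphenyl gives a 3.6-fold lower number from compound 2 to compound 3 (0.56 log units; beyond the scatter) in this assay, so this position has now produced a step beyond the scatter in each direction, the other being a 2.6-fold higher number from compound 1 to compound 2 (0.41 log units; beyond the scatter). The remaining step, a 1.4-fold lower number from compound 1 to compound 3 (0.15 log units; within the scatter), does not separate 2-chlorophenyl from 4-methoxyphenyl, which leaves compound 2 as the only one of the three set apart, with a higher number than both others. Nothing measured here bears on the reason for these differences.

From the compounds shown here alone, it remains open whether 4-hydroxyphenyl would read with 3-hydroxyphenyl or with 4-methoxyphenyl, a comparison that would separate the identity of the substituent from its place on the ring. Also open, going by these compounds, is how a phenyl ring carrying an amine or a carboxylic acid would read in this assay.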